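The compounds below may be only part of what the source reports. "The series", "measured", "known", "first", "only" and "open" are said of these compounds alone.

Compound 2 `C[C@@H](F)[C@H]1C(=O)N2C(C(=O)O)=C(C(C)(C)C)O[C@H]12` has been measured in an ADME assay, in phosphate buffer, at 28 degrees C, at pH 7.0 (on this read-out lower numbers stand for a shorter-lived compound and higher numbers for a longer-lived compound), where compound 2 gives 3.5 h. For the measured compounds named here, only one other compound has a number in this assay, compound 1 `COC(=O)[C@@H](O)[C@H]1C(=O)N2C(C(=O)O)=C(C(C)(C)C)O[C@H]12`, which gives 6.2 h; compound 2 sits at the other end of this pair, and the gap between them, a 1.8-fold lower number from compound 1 to compound 2 (0.25 log units; within the scatter), lies within the scatter of repeated measurements. Compound 3 `CC(C)(C)C1=C(C(=O)O)N2C(=O)[C@H](CN)[C@H]2O1` has not yet been measured. Its difference from compound 2 is aminomethyl in place of 1-fluoroethyl on a saturated ring carbon. Going by the values given here, the one measured step that bears on this change is the exchange of groups at the same saturated ring carbon between compound 1 and compound 2, and that step, a 1.8-fold lower number from compound 1 to compound 2 (0.25 log units; within the scatter), stayed within the scatter. Among the compounds with values here, on that basis no step beyond the scatter is expected in this assay for compound 3, in either direction, with the single measured step giving no firm pointer to a direction. The expected half-life of compound 3 is therefore 4 h, with a range from 1.5 h to 10 h, which would mean an estimated step of a 1.1-fold higher number from compound 2 to compound 3 (0.06 log units; within the scatter).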

Compound 3, half-life: 1.2 h
The estimate for compound 3 lay 3.3-fold (0.52 log units) above the measured number; the measured number lies below the stated range.
By their numbers in this assay, from the lowest: compound 3; then compounds 2 and 1 (each within the scatter of the next).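

This saturated ring carbon of the four-membered ring can shift the half-life in this assay beyond the scatter, which the earlier pair did not show: replacing 1-fluoroethyl with aminomethyl gives a clear drop (a 2.9-fold lower number from compound 2 to compound 3 (0.46 log units; beyond the scatter)). Aminomethyl also falls short of the hydroxy(methoxycarbonyl)methyl group at the same carbon (a 5.2-fold lower number from compound 1 to compound 3 (0.71 log units; beyond the scatter)), so among these three compounds it alone stands apart, while the other two groups remain within the scatter of each other. Nothing available explains why this group gives the shortest half-life of the three.

The compounds shown do not separate the effect of the amine nitrogen from that of the chain carrying it, so a hydroxymethyl group, with oxygen in place of that nitrogen, or a longer 2-aminoethyl chain could land near compound 3 or near compound 2. Three groups at one carbon also cannot show whether the drop seen with aminomethyl would persist if the amine were made a dimethylamino group or an amide.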